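The source may report more compounds than this note shows. Statements on the series, on what has been measured and on what is new or still open speak of the compounds shown alone.

Measured so far in an assay on FRT cells with Cystic fibrosis transmembrane conductance regulator variant F508del (Homo sapiens) as the target, read by fluorescence, with a stated time of 25 min; on this read-out higher numbers stand for larger maximal responses and lower numbers for smaller maximal responses:
compound 1 `NC(=O)CN1CCN(c2nc(-c3ccccn3)nc3c2CN(Cc2ccccc2)CC3)CC1` gives 57.9%;
compound 2 `CN1CCN(CCCNc2nc(-c3ccccn3)nc3c2CN(Cc2ccccc2)CC3)CC1` gives 53.4%.

Of the two numbers, that of compound 2 is the lower, and the gap to compound 1 is within the scatter. Among the measured compounds shown here, the only measured step, a number 4.5 percentage points lower from compound 1 to compound 2 (within the scatter), lies within the scatter as well. Compound 3 `CN(C)CCN1CCN(c2nc(-c3ccccn3)nc3c2CN(Cc2ccccc2)CC3)CC1` differs from compound 2 by 4-(2-(dimethylamino)ethyl)piperazin-1-yl in place of (3-(4-methylpiperazin-1-yl)propyl)amino on an aromatic carbon. For the measured compounds named here, with only that one step bearing on the change, and it within the scatter, no step beyond the scatter is expected in this assay; the estimated step is a number 1.6 percentage points higher from compound 2 to compound 3 (within the scatter). Compound 3 is therefore estimated at 55%, with a range from 43% to 67%.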

Compound 3, largest response reached (Emax), in percent of the reference or control that the assay uses: 41.3%
For compound 3 the middle estimate is 13.7 percentage points above the measured one; the measured number lies below the stated range.
By their numbers in this assay, from the lowest: compound 3; then compounds 2 and 1 (each within the scatter of the next).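

In this assay this aromatic carbon now shows a step beyond the scatter: a number 12.1 percentage points lower from compound 2 to compound 3 (beyond the scatter) when 4-(2-(dimethylamino)ethyl)piperazin-1-yl replaces (3-(4-methylpiperazin-1-yl)propyl)amino, two groups of the same atoms joined differently. With the piperazine kept in place, the chain end also counts: a number 16.6 percentage points lower from compound 1 to compound 3 (beyond the scatter) with (dimethylamino)methyl in place of carbamoyl. No measurement at hand gives a cause for either step. Open, going by these compounds, is whether a carboxylic acid in place of the carbamoyl would match compound 1, and how a longer chain carrying the dimethylamino group would read.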